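Adding a chloro group beside a nitro-bearing ring

The source may hold more compounds than are shown below. What is called first, only, known or untested is meant among the compounds shown, and "the series" means these compounds.

Compound 3 `O=C(/C=C/c1cccc([N+](=O)[O-])c1)c1ccco1` stands second highest among the three numbers measured in a functional assay on HL-60 cells (Homo sapiens) for inhibition, read by MTT assay, with a stated time of 48 h; a higher number here means a weaker inhibitor, a lower number a stronger inhibitor; in this assay compound 3 gives 14000 nM. Compound 2 `O=C(/C=C/c1ccccc1Cl)c1ccco1` gives 12000 nM in this assay, and the gap between compound 3 and compound 2 lies within the scatter. Compound 1 `O=C(/C=C/c1cc([N+](=O)[O-])ccc1Cl)c1ccc[nH]1` gives 38000 nM in this assay, and the gap between compound 3 and compound 1 lies beyond the scatter. Compound 4 `O=C(/C=C/c1cc([N+](=O)[O-])ccc1Cl)c1ccco1` differs from compound 3 by chloro in place of hydrogen on an aromatic carbon. Among the measured compounds shown here, no step between measured compounds tells how this change behaves on this core, so the expected step from compound 3 to compound 4 is small, a 1.4-fold higher number from compound 3 to compound 4 (0.15 log units; within the scatter), and may stay within the scatter. Compound 4 is therefore estimated at 20000 nM, with a likely range from 7000 nM to 60000 nM.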

Compound 4, half-maximal inhibitory concentration: 58000 nM
For compound 4 the middle estimate is 2.9-fold (0.46 log units) below the measured one, and the stated range covers the measured number.
By their numbers in this assay, from the lowest: compounds 2 and 3 (each within the scatter of the next); then compounds 1 and 4 (each within the scatter of the next).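

In this assay, chloro in place of hydrogen, para to a nitro group, gives a weaker inhibitor: a 4.1-fold higher number from compound 3 to compound 4 (0.62 log units; beyond the scatter). Nitro in place of hydrogen on the chloro-bearing ring also gives a weaker inhibitor: a 4.8-fold higher number from compound 2 to compound 4 (0.68 log units; beyond the scatter). Furan-2-yl in place of 1H-pyrrol-2-yl on a carbonyl carbon shows no clear difference: a 1.5-fold higher number from compound 1 to compound 4 (0.18 log units; within the scatter). Nothing available here accounts for these steps. On these data alone, whether fluoro or an amine in place of this chloro would give a similar step remains open.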